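The source may hold more compounds than are shown below. What is called first, only, known or untested is meant among the compounds shown, and "the series" means these compounds.

Going by the values given here, in a functional assay on PC-3 cells (Homo sapiens) for inhibition, read by MTT assay, with a stated time of 48 h, tested at 10 uM (on this read-out lower numbers stand for less inhibition of growth and higher numbers for more inhibition of growth at the one concentration tested), compound 2 `COc1ccc(C(O)c2c(C)oc3c([C@H]4CCN(C)C[C@H]4O)c(O)cc(O)c3c2=O)cc1Br` gives 0%, the lower of the two numbers so far, while compound 1 `Cc1oc2c([C@H]3CCN(C)C[C@H]3O)c(O)cc(O)c2c(=O)c1C(O)c1ccccc1Br` gives 45%. Compound 3 `Cc1oc2c([C@H]3CCN(C)C[C@H]3O)c(O)cc(O)c2c(=O)c1C(O)c1cccc(Cl)c1Cl` keeps the shared core and carries 2,3-dichlorophenyl in place of 3-bromo-4-methoxyphenyl on a saturated chain carbon bound to an aromatic carbon and an oxygen on a saturated carbon. Among the compounds with values here, only one measured step bears on this change: a number 45 percentage points lower from compound 1 to compound 2 (beyond the scatter), a large step made at the same place when 3-bromo-4-methoxyphenyl replaced 2-bromophenyl. Like compound 1, with its 45%, compound 3 has no methoxy group on that phenyl, although a single step is thin support and the halogens differ. A rise beyond the scatter is therefore expected in this assay, estimated as a number 32 percentage points higher from compound 2 to compound 3 (beyond the scatter). For compound 3 the expected value is 32%, within an estimated range of 8% to 58%.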

Compound 3, percent growth inhibition at one concentration: 20%
Compound 3: the middle estimate sits 12 percentage points above what was measured; low and high end bracket the measured number.
By their numbers in this assay, from the lowest: compound 2; then compound 3; then compound 1.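

In this assay, the place on a saturated chain carbon bound to an aromatic carbon and an oxygen on a saturated carbon now shows three distinct levels rather than two. Putting 2,3-dichlorophenyl in place of 3-bromo-4-methoxyphenyl gives a number 20 percentage points higher from compound 2 to compound 3 (beyond the scatter), so growth inhibition at this position is not confined to 2-bromophenyl. Yet 2,3-dichlorophenyl in place of 2-bromophenyl gives a number 25 percentage points lower from compound 1 to compound 3 (beyond the scatter), so two halogen-bearing phenyl groups without a methoxy group also differ beyond the scatter.

The compounds shown leave open whether the methoxy group alone sets compound 2 apart, since 3-bromo-4-methoxyphenyl differs from the other two groups in more than that group, and how a phenyl carrying an amine or a carboxylic acid would read at this place. Nothing measured here accounts for these differences.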